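The source may report more compounds than this note shows. Statements on the series, on what has been measured and on what is new or still open speak of the compounds shown alone.

Measured so far:
compound 1 `Oc1ccc(Br)cc1/C=N/c1ccc(OCc2ccccc2)cc1` — 31700 nM
compound 2 `Cc1ccc(O)c(/C=N/c2ccc(OCc3ccccc3)cc2)c1` — 24600 nM

In an assay on isolated protein for inhibition of Amine oxidase [flavin-containing] B (Homo sapiens), read by fluorescence and Amplex Red, with stated times of 15 min and 20 min (on this read-out lower numbers stand for stronger inhibition and higher numbers for weaker inhibition), compound 1 gives 31700 nM, the higher of the two numbers; compound 2 gives 24600 nM. For the measured compounds named here, the only measured step is a 1.3-fold lower number from compound 1 to compound 2 (0.11 log units; within the scatter), a methyl for a bromo, within the scatter. Compound 3 `Oc1c(Br)cc(Br)cc1/C=N/c1ccc(OCc2ccccc2)cc1` differs from compound 1 by bromo in place of hydrogen on an aromatic carbon. Going by the values given here, no measured step adds a bromo to the ring, so nothing in this assay points to a shift beyond the scatter. Compound 3 is estimated at 25000 nM, with a range of 10000 nM to 60000 nM. The expected step is a 1.3-fold lower number from compound 1 to compound 3 (0.10 log units; within the scatter).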

Compound 3, half-maximal inhibitory concentration: 10800 nM
Compound 3: the middle estimate sits 2.3-fold (0.36 log units) above what was measured; the measured number falls inside the stated range.
By their numbers in this assay, from the lowest: compound 3; then compounds 2 and 1 (each within the scatter of the next).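

In (this assay), bromo in place of hydrogen on the aromatic carbon ortho to a hydroxy group gives a step beyond the scatter (a 2.9-fold lower number from compound 1 to compound 3 (0.47 log units; beyond the scatter)), while methyl in place of bromo stays within it (a 1.3-fold lower number from compound 1 to compound 2 (0.11 log units; within the scatter)). This carbon therefore responds to substitution, though only modestly. No available evidence bears on the origin of this step.

From the compounds shown here alone, whether chloro or an amine on this carbon gives a step of similar size remains open. So does whether the step persists when a methoxy group replaces the hydroxy group.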